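This account rests on a few compounds, and the source may have more. Where it says the series, first, only, none or still open, it means among the compounds named here.

Measured compounds:
Compound 1 `ClCc1ccccc1Cn1cnc2c(Cl)ncnc21`: 10500 nM
Compound 2 `ClCc1cccc(Cn2cnc3ncnc(Cl)c32)c1`: 3090 nM

Of the compounds shown here, two have been measured in a functional assay on UO-31 cells (Homo sapiens) for cytotoxicity, read by sulforhodamine B assay, with a stated time of 48 h; a higher number here means a weaker inhibitor of growth, a lower number a stronger inhibitor of growth. In this assay compound 1 gives 10500 nM, while compound 2 gives 3090 nM. Of the two numbers, compound 2 holds the lower one and compound 1 the higher, and the gap between them is wider than the usual scatter of the assay, so compound 2 is the stronger of the pair as far as these two values go.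

The next compound, compound 3 `ClCc1cccc(Cn2cnc3nc(Cl)nc(Cl)c32)c1`, keeps the whole of compound 2 and differs from it in one place: chloro in place of hydrogen on an aromatic carbon. Among the compounds with values here, no step of this kind between measured compounds is available, so there is nothing in the data to set its size or direction. The expectation is therefore cautious: a step from compound 2 to compound 3 of a 1.2-fold lower number from compound 2 to compound 3 (0.09 log units; within the scatter) is estimated, which is to say none beyond the scatter in either direction. On that basis compound 3 is expected to give about 2500 nM in this assay, with a plausible range from 900 nM to 8000 nM.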

Compound 3, concentration for total growth inhibition: 35500 nM
Beside the measured number, compound 3's estimate is 14-fold (1.15 log units) below it, and the stated range ends below it.
By their numbers in this assay, from the lowest: compound 2; then compound 1; then compound 3.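

Chloro in place of hydrogen on this aromatic carbon, between two ring nitrogen atoms, gives in this assay an 11-fold higher number from compound 2 to compound 3 (1.06 log units; beyond the scatter) and so marks a large move toward weaker growth inhibition. Compounds 1 and 2 both carry hydrogen at this carbon, so they gave no sign of how the position would respond to substitution. This pair shows that the position is sensitive and that one added chlorine atom, with the rest of compound 2 unchanged, is enough to weaken growth inhibition well beyond the scatter. The data shown offer no measurement that accounts for this step.

Whether the loss belongs to chloro specifically or would follow from any group at this carbon remains open, as the compounds shown include no amine, methoxy group or fluoro there. Within the data shown here, also open is whether the same step would appear with the chloromethyl group placed as in compound 1, since this change has been read on only one pair.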